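Swapping the Aniline Ring on a Cinnamamide Scaffold

The source may report more compounds than this note shows. Statements on the series, on what has been measured and on what is new or still open speak of the compounds shown alone.

Compound 1 `C#Cc1cccc(Nc2ncnc3cc(NC(=O)/C=C/c4ccccc4)sc23)c1` gives 15400 nM in a functional assay on HepG2 cells (Homo sapiens) for antiproliferative activity, read by MTT assay, with a stated time of 48 h (a lower number here means a stronger inhibitor, a higher number a weaker inhibitor), the lowest of the three numbers measured. Compound 3 `O=C(/C=C/c1ccccc1)Nc1cc2c(Nc3ccc(Cl)c(Cl)c3)ncnc2s1` gives 30100 nM, and compound 2 `O=C(/C=C/c1ccc(O)cc1)Nc1cc2c(Nc3ccc(Cl)c(Cl)c3)ncnc2s1` gives 42900 nM; the step of a 1.4-fold lower number from compound 2 to compound 3 (0.15 log units; within the scatter) shows the loss of the hydroxy changes little. Compound 4 `O=C(/C=C/c1ccccc1)Nc1cc2ncnc(Nc3ccc(Cl)c(Cl)c3)c2s1` differs from compound 1 by 3,4-dichlorophenyl in place of 3-ethynylphenyl on a nitrogen on an aromatic ring. For the measured compounds named here, no measured step isolates this exact change; the values of compound 1 and compound 3 carry the same aryl swap but on a differently arranged core, and they lie close together. Compound 4 is therefore expected to show a modest weakening at most, a 1.6-fold higher number from compound 1 to compound 4 (0.21 log units; within the scatter), with an estimated value of 25000 nM, in a range from 8000 nM to 75000 nM.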

Compound 4, half-maximal inhibitory concentration: 13400 nM
Compound 4: the middle estimate sits 1.9-fold (0.27 log units) above what was measured, and the stated range covers the measured number.
By their numbers in this assay, from the lowest: compounds 4, 1, 3 and 2 (each within the scatter of the next, the first and the last beyond it).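

In this assay the swap of 3-ethynylphenyl for 3,4-dichlorophenyl on the shared core gives a 1.1-fold lower number from compound 1 to compound 4 (0.06 log units; within the scatter) and so stays within the scatter: on this nitrogen, the two rings cannot be told apart. For the compounds shown here, the earlier compounds held no pair differing only here, so this is the first direct reading of the change. No measurement at hand bears on why the two rings read alike.

From the compounds shown here alone, whether a phenyl ring carrying an amine or a carboxylic acid would read the same on this nitrogen remains open. Also open, going by these compounds, is whether adding a hydroxy to the cinnamamide ring would change as little on this core.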